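Aryl ether to aryl thioether on the shared core

This account rests on a few compounds, and the source may have more. Where it says the series, first, only, none or still open, it means among the compounds named here.

Among the measured compounds shown here, compound 1 `Nc1cc(N)c2nc(-c3ccccc3)c(Oc3ccc(Cl)c(Cl)c3)nc2c1` is the one member of the series with a numeric read-out: in a functional assay on U-251 cells (Homo sapiens) for inhibition, read by sulforhodamine B assay, with a stated time of 48 h (a lower number here means that less compound is tolerated, a higher number that more compound is tolerated), compound 1 gives 83200 nM, so it stands as the single fixed point among the values shown. Compound 2 `CCOC(=O)[C@H](CCC(=O)O)NC(=O)c1ccc(CNc2nc3cc(N)cc(N)c3nc2-c2ccccc2)cc1` is recorded only as a limit of the assay and not a number; in this assay compound 2 gives < 100000 nM, which is the case described by the limit of < 100000 nM in this assay, at which 1 of the 2 values shown sits. Compound 3 `Nc1cc(N)c2nc(-c3ccccc3)c(Sc3ccc(F)cc3)nc2c1` has not been measured in this assay. The change from compound 1 is (4-fluorophenyl)sulfanyl in place of 3,4-dichlorophenoxy on an aromatic carbon of the shared core, next to the ring nitrogen and ortho to a phenyl group. For the measured compounds named here, no step between measured compounds bears on this exchange, so no direction can be drawn from the data. Compound 3 is expected to stay within the usual scatter of compound 1, the step of a 1.0-fold lower number from compound 1 to compound 3 (0.02 log units; within the scatter) being estimated as none beyond scatter. The expected value for compound 3 in this assay is therefore 80000 nM, with a range from 30000 nM to 200000 nM.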

Compound 3, concentration lethal to 50% of the cells: 61700 nM
Compound 3: the middle estimate sits 1.3-fold (0.11 log units) above what was measured, and the stated range covers the measured number.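

In this assay, among the compounds shown here, the exchange of 3,4-dichlorophenoxy for (4-fluorophenyl)sulfanyl gives a 1.3-fold lower number from compound 1 to compound 3 (0.13 log units; within the scatter), the first step that can be read at this position, on an aromatic carbon next to the ring nitrogen and ortho to a phenyl group. For the compounds shown here, the position therefore takes this thioether in place of the aryl ether with no change in the read-out beyond the scatter, although the linking atom and the ring halogens are exchanged together, so the single step cannot separate the two. Nothing measured here accounts for the result.

Still open, as far as these compounds go, is whether any group at this position moves the number beyond the scatter. A phenylamino group, or a carboxylic acid on the outer ring, would test this, and separate exchanges of the linking atom and the halogens would show what each contributes.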